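This account rests on a few compounds, and the source may have more. Where it says the series, first, only, none or still open, it means among the compounds named here.

Three close analogues share one core and have been run in a functional assay on the whole organism for inhibition, with Nicotiana tabacum as the target; a lower number here means a stronger inhibitor, a higher number a weaker inhibitor. Compound 1 `Cc1nc(Nc2ccc(Br)cc2)c2cc[nH]c2n1` gives 170000000 nM, compound 3 `Cc1nc(Nc2ccc(N)cc2)c2cc[nH]c2n1` gives 195000000 nM, and compound 2 `CCc1ccc(Nc2[nH]c(C)nc3nccc2-3)cc1` gives 214000000 nM. Within the data shown here, the single one-place step among them, a 1.1-fold higher number from compound 1 to compound 3 (0.06 log units; within the scatter), shows that swapping the group on the aromatic carbon of the aniline leaves the read-out essentially where it was. On these numbers compound 2 sits nearest to compound 3 and furthest from compound 1, and both of those gaps fall inside the usual scatter, so nothing separates the three.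

Compound 4 `Cc1nc2nccc-2c(Nc2ccc(C(C)C)cc2)[nH]1` is not yet measured. It differs from compound 2 by methyl in place of hydrogen on a saturated chain carbon bound to an aromatic carbon and a saturated chain carbon, read one bond further out as ethyl to isopropyl. Among the measured compounds shown here, the only measured step that bears on this, from compound 1 to compound 3, altered the same para group of the aniline and moved nothing beyond the scatter, and all three measured values cluster tightly. The expectation for compound 4 in this assay is therefore no step beyond the scatter, no change at the digits printed from compound 2 to compound 4 (within the scatter), and compound 4 is estimated at 214000000 nM, within a range of 100000000 nM to 450000000 nM.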

Compound 4, half-maximal inhibitory concentration: 45700000 nM
Compound 4: middle estimate off by 4.7-fold (0.67 log units), on the high side; the measured number lies below the stated range.
By their numbers in this assay, from the lowest: compound 4; then compounds 1, 3 and 2 (each within the scatter of the next).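

In this assay, the change from ethyl to isopropyl gives a 4.7-fold lower number from compound 2 to compound 4 (0.67 log units; beyond the scatter) and is the first step among these compounds to pass beyond the scatter. Among these compounds, the only earlier step, a 1.1-fold higher number from compound 1 to compound 3 (0.06 log units; within the scatter), exchanged bromo for amino on an aromatic carbon and left the read-out within the scatter, so the close grouping of the first three compounds does not mean that the read-out ignores every change: methyl in place of hydrogen on a saturated chain carbon bound to an aromatic carbon and a saturated chain carbon, a change of one carbon atom, is enough to shift it. No measurement shown here offers an explanation for this shift.

As far as these compounds go, whether the lower number follows from branching at this carbon or simply from the added carbon remains open, and a straight propyl chain or a tert-butyl group in the same place would be needed to tell these apart. Among the compounds shown here, what a cyclopropyl ring, a methoxy group or a carboxylic acid would do there is equally open, and with only one step of this kind it is also unknown whether the shift would recur on another member of the series.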